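Lengthening the Methoxyalkyl Chain on the Amine

The compounds below may be only part of what the source reports. "The series", "measured", "known", "first", "only" and "open" are said of these compounds alone.

Measured so far:
compound 1, `COc1cc(/C=C/C(=O)/C=C(/C=C/c2ccc(O)c(OC)c2)NCCCO)ccc1O`: 89.9%
compound 2, `COCCNC(=C\C(=O)/C=C/c1ccc(O)cc1)/C=C/c1ccc(O)cc1`: 75.1%

In an ADME assay on CHO-K1 cells (Cricetulus griseus) for activation, read by fluorescence, tested at 10 uM (a lower number here means a stronger effect, a higher number a weaker effect of the compound at the concentration tested), compound 2 holds the lowest of the two numbers, and compound 1 lies higher by a gap beyond the usual scatter. These two differ in more than one place, so their values say nothing about any single change on their own.

Compound 3, `COCCCNC(=C\C(=O)/C=C/c1ccc(O)cc1)/C=C/c1ccc(O)cc1`, has not yet been tested. It differs from compound 2 in one place: methoxymethyl in place of methoxy on a saturated chain carbon, two bonds along the chain from an amine nitrogen. No step of this kind has been measured among the compounds shown, so there is nothing to lean on for its direction. The expected step from compound 2 to compound 3 in this assay is a number 0.1 percentage points lower from compound 2 to compound 3 (within the scatter), which is none beyond the scatter. For compound 3 the estimate in this assay is 75%, within a range from 60% to 90%.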

Compound 3, a percentage reported as activity, at one concentration (the size of the read-out at that concentration, not a potency): 97%
Estimate against measurement, compound 3: 22 percentage points below; the whole stated range lies below it.
By their numbers in this assay, from the lowest: compound 2; then compounds 1 and 3 (each within the scatter of the next).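

In this assay the read-out comes out a number 21.9 percentage points higher from compound 2 to compound 3 (beyond the scatter) and this is the first single change that can be read among these compounds. It shows that the chain on the amine nitrogen is not a silent place: replacing (2-methoxyethyl)amino with (3-methoxypropyl)amino, with the rest of the core unchanged, weakens the effect at the concentration tested by more than the scatter. Nothing available here explains why this small change in the chain has such an effect.

With only two chain lengths, the compounds shown cannot tell whether the weakening continues, levels off or reverses in a longer chain such as 4-methoxybutyl. Also open, going by these compounds, is whether the ether oxygen matters at all, which a plain butyl chain or a 2-ethoxyethyl chain on the same nitrogen would help to settle.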